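Cytotoxicity notes on an endoperoxide series

A few compounds are considered here, and "the series" means these few. Any claim that something is new, unique, unknown or untested is made for them only; others in the source may bear on it.

Measured so far in an ADME assay on L02 cells (Homo sapiens) for cytotoxicity, read by MTT assay, with a stated time of 48 h; a higher number here means a weaker inhibitor, a lower number a stronger inhibitor:
- Compound 1 `O=C(NO)[C@H]1CC[C@]2(CC1)OO[C@]1(O2)C2CC3CC(C2)CC1C3` gives > 50000 nM; this value is a limit of the assay, not a number.
- Compound 2 `O=C(O)[C@H]1CC[C@]2(CC1)OO[C@]1(O2)C2CC3CC(C2)CC1C3` gives > 100000 nM; this value is also a limit, not a number.
- Compound 3 `O=C(NO)[C@H]1CC[C@@]2(CC1)OC[C@]1(OO2)C2CC3CC(C2)CC1C3` gives > 50000 nM; this value is likewise a limit.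

All three values sit at limits: the limit of > 100000 nM in this assay, at which 1 of the 3 values shown sits, and (the limit of > 50000 nM in this assay, at which 2 of the 3 values shown sit). The change from compound 1 to compound 2 is hydroxy in place of hydroxyamino on a carbonyl carbon; its step in this assay is a step that the two limits leave unreadable from compound 1 to compound 2, so nothing can be read from it about size. Compound 3 carries a different core; how the two cores differ is not broken down here. Compound 4 `O=C(O)[C@H]1CC[C@@]2(CC1)OC[C@]1(OO2)C2CC3CC(C2)CC1C3` is not yet measured. It stands to compound 3 as compound 2 stands to compound 1, and the change hydroxy in place of hydroxyamino on a carbonyl carbon is the same kind of change, since both act on a carbonyl carbon whose other neighbours are a saturated ring carbon. Because compound 3 sits at a limit > 50000 nM and compound 1 and compound 2 both return only limits, the step that the limit leaves unreadable from compound 3 to compound 4 is expected to be unreadable. Compound 4 is expected to give about 100000 nM in this assay, most likely as a limit rather than a number.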

Compound 4, half-maximal inhibitory concentration: > 100000 nM
Compound 4: a limit, no number (the forecaster's own chance of this, stated with the estimate: 90%); the middle value sits exactly at the limit.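

In this assay compound 4 gives > 100000 nM, which is a limit and not a number. Compound 3 also stands at a limit, and no size can be read for the step between compound 3 and compound 4. The compounds shown leave open whether hydroxy in place of hydroxyamino on a carbonyl carbon changes cytotoxicity in this assay on either core.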